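The source may hold more compounds than are shown below. What is called first, only, known or untested is meant among the compounds shown, and "the series" means these compounds.

Working notes on the sulfonamide series. Among the measured compounds shown here, in a functional assay on Capan-2 cells (Homo sapiens) for inhibition, read by MTT assay, with a stated time of 72 h (a lower number here means a stronger inhibitor of growth, a higher number a weaker inhibitor of growth), compound 1 `O=S(=O)(NCCCCNCc1ccc(Br)cc1)c1cc(C(F)(F)F)cc(C(F)(F)F)c1` gives 1900 nM, the lowest of the three numbers so far; compound 2 `CC(C)(C)c1ccc(CNCCCNS(=O)(=O)c2cc(C(F)(F)F)cc(C(F)(F)F)c2)cc1` gives 2100 nM, within the scatter of compound 1, while compound 3 `O=S(=O)(NCCCNCc1cccc(Cl)c1)c1cc(C(F)(F)F)cc(C(F)(F)F)c1` gives 8000 nM. Compound 4 `O=S(=O)(NCCCNCc1ccccc1Cl)c1cc(C(F)(F)F)cc(C(F)(F)F)c1` is not yet measured. It differs from compound 1 by (2-chlorobenzyl)amino in place of ((4-bromobenzyl)amino)methyl on a saturated chain carbon, three bonds along the chain from a sulfonamide nitrogen. The two steps that bear on this change both point the same way: a 4.2-fold higher number from compound 1 to compound 3 (0.62 log units; beyond the scatter) and a 3.8-fold higher number from compound 2 to compound 3 (0.58 log units; beyond the scatter), each a modest weakening when the 3-chlorobenzyl group enters. A comparable modest step upward in this assay is therefore expected for compound 4, as a 3.2-fold higher number from compound 1 to compound 4 (0.50 log units; beyond the scatter). Compound 4 is estimated at 6000 nM, with a range of 2500 nM to 15000 nM.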

Compound 4, concentration for 50% growth inhibition: 13000 nM
For compound 4 the middle estimate is 2.2-fold (0.34 log units) below the measured one, and the stated range covers the measured number.
By their numbers in this assay, from the lowest: compounds 1 and 2 (each within the scatter of the next); then compounds 3 and 4 (each within the scatter of the next).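

In this assay the upward step seen with the 3-chlorobenzyl group recurs with the (2-chlorobenzyl)amino group, as a 6.8-fold higher number from compound 1 to compound 4 (0.84 log units; beyond the scatter) and a 6.2-fold higher number from compound 2 to compound 4 (0.79 log units; beyond the scatter). 2-chlorophenyl in place of 3-chlorophenyl gives a 1.6-fold higher number from compound 3 to compound 4 (0.21 log units; within the scatter), so these two chlorinated compounds cannot be ordered. No supporting measurement bears on these steps. Open, from the compounds shown here alone, is whether a 4-chlorobenzyl group on the chain of compound 4 would bring the number down to those of compound 1 and compound 2, and whether an amide in place of the amine would keep those numbers.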